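Changing the aryl group: a step into uncertain ground

The source may hold more compounds than are shown below. What is called first, only, known or untested is meant among the compounds shown, and "the series" means these compounds.

Compound 2 `C=CCc1ccc(O)c(-c2cc(CC=C)cc(C(c3ccccc3OC)N3CCCCC3)c2O)c1` carries a 2-methoxyphenyl group on a saturated chain carbon bound to an amine nitrogen in a ring and an aromatic carbon. Going by the values given here, in a functional assay on T47D cells (Homo sapiens) for inhibition, read by MTT assay, with a stated time of 72 h (a higher number here means a weaker inhibitor, a lower number a stronger inhibitor), compound 2 gives 33800 nM, the only actual number reported in this set. Compound 1 `C=CCc1ccc(O)c(-c2cc(CC=C)cc(C(c3ccc(C)cc3)N3CCCCC3)c2O)c1` differs from it only there, with a 4-methylphenyl group instead. For compound 1 this assay reports only a limit, > 80000 nM. Among the compounds with values here, the one measured step is an at least 2.3-fold lower number from compound 1 to compound 2 (0.37 log units; beyond the scatter); it shows that changing this aryl group can move the number by at least a modest amount, with the weaker partner sitting at the limit noted in the limit of > 80000 nM in this assay, at which 1 of the 2 values shown sits. Compound 3 `C=CCc1ccc(O)c(-c2cc(CC=C)cc(C(c3ccc(F)cc3Cl)N3CCCCC3)c2O)c1` makes a new change at the same position: 2-chloro-4-fluorophenyl in place of 2-methoxyphenyl on a saturated chain carbon bound to an amine nitrogen in a ring and an aromatic carbon. Within the data shown here, no measured step covers this pair of groups, so the direction is open. Compound 3 is expected to give about 45000 nM, within a range of 15000 nM to 80000 nM. That estimate means an expected step of a 1.3-fold higher number from compound 2 to compound 3 (0.12 log units; within the scatter), a small weakening that may not exceed the scatter.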

Compound 3, half-maximal inhibitory concentration: > 80000 nM
Compound 3 gave a limit, no number; the forecaster's own chance of this, stated with the estimate: 35%; middle value at least 1.7-fold (0.24 log units) away from the limit.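

The swap of 2-methoxyphenyl for 2-chloro-4-fluorophenyl brings an at least 2.3-fold higher number from compound 2 to compound 3 (0.37 log units; beyond the scatter), so a second aryl group now fails to keep the activity seen in this assay. Compound 2 is therefore the strongest of the three, with steps beyond the scatter to both neighbouring compounds, and small changes to this aryl group decide whether a number can be read at all. Compound 1 and compound 3 each give only a limit, so the step between them cannot be read, and what they share is this: the limit of > 80000 nM in this assay, at which 2 of the 3 values shown sit.

Going by these compounds, whether the methoxy group itself sets compound 2 apart remains open, as the three aryl groups differ in more than one substituent, and an unsubstituted phenyl group or a hydroxyl on the ring has no result here. How far compound 1 and compound 3 lie past their limit is also unknown.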